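Replacing a Hydroxy Group with Fluoro: Expected Clearance

A few compounds are considered here, and "the series" means these few. Any claim that something is new, unique, unknown or untested is made for them only; others in the source may bear on it.

Measured so far in an ADME assay on cells (Hepatocyte, Rattus norvegicus) for metabolic stability; a lower number here means slower removal, a higher number faster removal of the compound:
compound 2 `Cc1ncccc1-c1cnc(NCc2c(F)cc(O)c3c2CCO3)n2cnnc12` gives 50 uL/min;
compound 3 `COc1cc(F)c(CNc2ncc(-c3cccnc3C)c3nncn23)c2c1OCC2` gives 4 uL/min;
compound 1 `Cc1ncccc1-c1cnc(NCc2c(F)cc(C3CC3)c3c2CCO3)n2cnnc12` gives "not determined" (no result reported).

For the measured compounds named here, compound 2 stands at the higher of the two numbers; its only measured neighbour is compound 3, and the step of a 13-fold lower number from compound 2 to compound 3 (1.10 log units; beyond the scatter) is large. Compound 4 `Cc1ncccc1-c1cnc(NCc2c(F)cc(F)c3c2CCO3)n2cnnc12` is not yet measured. It differs from compound 2 in one place: fluoro in place of hydroxy on an aromatic carbon. Going by the values given here, only one measured step bears on this change: methyl in place of hydrogen on an oxygen on an aromatic ring, which gave a 13-fold lower number from compound 2 to compound 3 (1.10 log units; beyond the scatter). Compound 4 also loses the hydroxy group, here in favour of fluoro, so a lower number than that of compound 2 is expected, although a different group enters and the size of the drop is uncertain. The step expected from this reasoning is a 4.2-fold lower number from compound 2 to compound 4 (0.62 log units; beyond the scatter). For compound 4 the estimate in this assay is 12 uL/min, with a range from 4 uL/min to 35 uL/min.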

Compound 4, intrinsic clearance in a liver preparation (reported as CLH), per the amount of preparation that the assay uses: 9 uL/min
Beside the measured number, compound 4's estimate is 1.3-fold (0.12 log units) above it; low and high end bracket the measured number.
By their numbers in this assay, from the lowest: compound 3; then compound 4; then compound 2.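

In this assay, the lower number seen with methoxy is not unique to that group: fluoro in place of hydroxy gives a 5.6-fold lower number from compound 2 to compound 4 (0.74 log units; beyond the scatter), so a lower number at this position does not depend on keeping an oxygen there. The replacement group still matters, as fluoro in place of methoxy gives a 2.3-fold higher number from compound 3 to compound 4 (0.35 log units; beyond the scatter), a modest step that leaves compound 4 between the other two compounds. No measurement shown explains why the hydroxy compound has the highest number or why the two replacements differ.

Going by these compounds, whether the number is set mainly by the loss of the hydroxy group or by the group that enters remains open. An amine, a chloro group or a carboxylic acid at this position could help separate these two readings, and the same change on a different core would show how far the result carries.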